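Compound 3 to compound 4: hydroxy becomes methoxy

A few compounds are considered here, and "the series" means these few. Any claim that something is new, unique, unknown or untested is made for them only; others in the source may bear on it.

Measured so far in a functional assay on MCF7 cells (Homo sapiens) for antiproliferative activity, read by sulforhodamine B assay, with a stated time of 48 h; a lower number here means a stronger inhibitor, a higher number a weaker inhibitor
- compound 1 `COc1cccc(/C=C/C(=O)C(=Cc2cc(OC)c(OC)c(OC)c2)C(=O)/C=C/c2cccc(OC)c2OC)c1OC` gives 840 nM
- compound 2 `COc1cc(C=C(C(=O)/C=C/c2cccc(OC)c2OC)C(=O)/C=C/c2cccc(OC)c2OC)cc(Br)c1O` gives 360 nM
- compound 3 `COc1ccc(OC)c(/C=C/C(=O)C(=Cc2ccc(O)c(OC)c2)C(=O)/C=C/c2cc(OC)ccc2OC)c1` gives 400 nM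

Compound 3 at 400 nM and compound 2 at 360 nM lie within the usual scatter of each other, while compound 1 shows a clearly higher number at 840 nM in the same test.

Compound 4 `COc1ccc(OC)c(/C=C/C(=O)C(=Cc2ccc(OC)c(OC)c2)C(=O)/C=C/c2cc(OC)ccc2OC)c1` differs from compound 3 by methyl in place of hydrogen on an oxygen on an aromatic ring and so has methyl in place of hydrogen on an oxygen on an aromatic ring, turning 4-hydroxy-3-methoxyphenyl into 3,4-dimethoxyphenyl.

For the measured compounds named here, one measured step bears on this change, and it is modest. It is a 2.3-fold lower number from compound 1 to compound 2 (0.37 log units; beyond the scatter) and there a methoxy gave way to a hydroxy. Read backwards, it links the methoxy form to the higher number. That step also brought in a bromo group, and its compounds carry different side rings, so it is only a loose guide. A small rise is therefore expected in this assay and it may not clear the scatter.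

The estimated step is a 1.5-fold higher number from compound 3 to compound 4 (0.18 log units; within the scatter) and would mean a slightly weaker inhibitor.

Compound 4 is thus estimated at 600 nM and expected to fall from 250 nM to 1300 nM when measured.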

Compound 4, half-maximal inhibitory concentration: 850 nM
Estimate against measurement, compound 4: 1.4-fold (0.15 log units) below; low and high end bracket the measured number.
By their numbers in this assay, from the lowest: compounds 2 and 3 (each within the scatter of the next); then compounds 1 and 4 (each within the scatter of the next).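

Adding one methyl to the ring oxygen gives a 2.1-fold higher number from compound 3 to compound 4 (0.33 log units; beyond the scatter) in this assay. This is the first pair shown in which hydroxy to methoxy is the only change, so the shift cannot come from a bromo group or from different side rings, as it could in the earlier step. At this position, then, the 4-hydroxy-3-methoxyphenyl compound is the stronger inhibitor and the 3,4-dimethoxyphenyl compound the weaker, by a modest margin, and nothing measured here explains why.

Still open, on these data alone, is whether an ethoxy group, a longer chain on that oxygen, or an amine in place of the hydroxy would move the number further. As far as these compounds go, it is also open whether the same change has a similar effect on compounds with the side rings of compound 1 or compound 2.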